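The source may hold more compounds than are shown below. What is called first, only, known or untested is meant among the compounds shown, and "the series" means these compounds.

Measured so far:
- compound 1 `CC(C)c1cc(-c2n[nH]c(=O)n2-c2cccc(C(=O)NCCCCCC(=O)NO)c2)c(O)cc1O`: 4600 nM
- compound 2 `CC(C)c1cc(-c2n[nH]c(=O)n2-c2cccc(NC(=O)CCCCCCC(=O)NO)c2)c(O)cc1O`: 1600 nM
- compound 3 `CC(C)c1cc(-c2n[nH]c(=O)n2-c2ccc(C(=O)NCCCCC(=O)NO)cc2)c(O)cc1O`: 4600 nM

All three values come from a functional assay on HEL cells (Homo sapiens) for inhibition; a lower number here means a stronger inhibitor, a higher number a weaker inhibitor. Compound 1 stands at the top of this small set of numbers, level with compound 3, the two being within the usual scatter of each other. Compound 2 has the lowest number, and its gap to compound 1 lies beyond the scatter, so compound 1 belongs to the weaker end of the three.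

The next compound to be tested is compound 4 `CNC(=O)CCCCCCCNC(=O)c1cccc(-n2c(-c3cc(C(C)C)c(O)cc3O)n[nH]c2=O)c1`. It has 2-(methylcarbamoyl)ethyl in place of hydroxycarbamoyl on a saturated chain carbon, five bonds along the chain from an amide-type nitrogen.

All three measured compounds end in hydroxycarbamoyl, so nothing measured yet shows what losing that group does in this assay. Among the measured compounds shown here, the only guide is the narrow spread of the measured compounds, and any forecast must stay wide. A small move towards a higher number, meaning a slightly weaker inhibitor, is the expectation, and it may not clear the scatter. The expected change is a 1.5-fold higher number from compound 1 to compound 4 (0.18 log units; within the scatter). For compound 4 the estimated value is 7000 nM, with an expected range from 2000 nM to 25000 nM.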

Compound 4, half-maximal inhibitory concentration: 4600 nM
Compound 4: the middle estimate sits 1.5-fold (0.18 log units) above what was measured; the measured number falls inside the stated range.
By their numbers in this assay, from the lowest: compound 2; then compounds 1, 3 and 4 (each within the scatter of the next).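

In this assay, the step of 2-(methylcarbamoyl)ethyl in place of hydroxycarbamoyl, on a saturated chain carbon, five bonds along the chain from an amide-type nitrogen, gives no change at the digits printed from compound 1 to compound 4 (within the scatter). Among the compounds shown here, this is the first pair that removes the hydroxycarbamoyl end shared by the earlier compounds, and it shows that, on this chain, the read-out stays level when that end is exchanged for a larger group with 6 heavy atoms instead of 4, and with 1 hydrogen-bond donor and 1 acceptor instead of 2 of each. No measurement here explains why the number holds steady, so the result stands as an observation only.

Still open, as far as these compounds go, is whether the same exchange would leave the number just as steady on the frameworks of compound 2 and compound 3, which differ from compound 1 in how the chain is attached. Also open, from the compounds shown here alone, is how this position responds to other chain ends, such as a carboxylic acid, an amine or a simple methyl group, and whether any of them would move the number beyond the scatter.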